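Amide variation and cytotoxicity: working notes

The compounds below may be only part of what the source reports. "The series", "measured", "known", "first", "only" and "open" are said of these compounds alone.

Measured so far:
compound 1, `COc1ccc2c(=O)c(/C=C/C(=O)Nc3cc(C)ccc3C)coc2c1`: 1100000 nM
compound 2, `Cc1ccc(CNC(=O)/C=C/c2coc3cc(O)ccc3c2=O)cc1`: 501000 nM

Both values come from an ADME assay on HepG2 2.2.15 cells (Homo sapiens) for cytotoxicity, read by MTT assay, with stated times of 48 h and 9 days; on this read-out higher numbers stand for lower toxicity in this test and lower numbers for higher toxicity in this test. Of these two numbers, compound 1 stands highest; compound 2 gives the lower number, and the gap between them lies beyond the usual scatter. For the measured compounds named here, no step between two measured compounds that differ in a single place is available, so the pair of compound 1 and compound 2 is read only as two values, not as a step.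

Compound 3, `COc1ccc2c(=O)c(/C=C/C(=O)NCc3ccccc3F)coc2c1`, has not yet been measured in this assay. It differs from compound 1 in one place: 2-fluorobenzyl in place of 2,5-dimethylphenyl on an amide-type nitrogen. The shared core and the amide-type nitrogen are unchanged. Going by the values given here, no measured step shows how this exchange acts on the read-out of this assay, so the expectation rests on compound 1 alone. For compound 3 a small downward step a 1.4-fold lower number from compound 1 to compound 3 (0.14 log units; within the scatter) is expected, of a size that may well stay within the scatter. Compound 3 is estimated at 800000 nM, with a range from 300000 nM to 2000000 nM.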

Compound 3, half-maximal cytotoxic concentration: 146000 nM
Beside the measured number, compound 3's estimate is 5.5-fold (0.74 log units) above it; the whole stated range lies above it.
By their numbers in this assay, from the lowest: compound 3; then compound 2; then compound 1.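

For the compounds shown here, this is the first step that can be read at a single place: in this assay, 2-fluorobenzyl in place of 2,5-dimethylphenyl on the amide-type nitrogen gives a 7.5-fold lower number from compound 1 to compound 3 (0.88 log units; beyond the scatter). The read-out therefore responds to a change at this nitrogen, even though both groups have the same count of heavy atoms, one six-membered aromatic ring, no hydrogen-bond donors or acceptors and no net charge. Nothing measured here bears on the reason for this step.

The exchange alters the phenyl-versus-benzyl form and the substituents on the ring together, and the compounds shown do not separate these two changes. An unsubstituted benzyl group or a longer chain such as 2-phenylethyl on the same nitrogen would bear on that question.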